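The source may hold more compounds than are shown below. What is called first, only, known or untested is meant among the compounds shown, and "the series" means these compounds.

For the measured compounds named here, in a functional assay on MDA-MB-231 cells (Homo sapiens) for inhibition, read by MTT assay, with a stated time of 72 h (a higher number here means a weaker inhibitor, a lower number a stronger inhibitor), compound 2 `CC(C)[C@H](NC(=O)c1cc(Cl)ccc1OCCCN)C(=O)Nc1ccc([N+](=O)[O-])cc1Cl` gives 6770 nM, the only actual number available so far. Its close relative, compound 1 `COC(=O)NCCOc1ccc(Cl)cc1C(=O)N[C@H](C(=O)Nc1ccc([N+](=O)[O-])cc1Cl)C(C)C`, is recorded at > 10000 nM, which is a limit of the assay and not a number. Going by the values given here, the single measured step between them is an at least 1.4-fold lower number from compound 1 to compound 2 (0.16 log units; that floor lies within the scatter), so it sets no firm size. Compound 3 `CC(C)[C@H](NC(=O)c1cc(Cl)ccc1OC1CCNCC1)C(=O)Nc1ccc([N+](=O)[O-])cc1Cl` carries a new change to the same side chain: piperidin-4-yl in place of 3-aminopropyl on an oxygen on an aromatic ring. In words, piperidin-4-yl stands in place of 3-aminopropyl on an oxygen on an aromatic ring. Among the compounds with values here, the only guide is an at least 1.4-fold lower number from compound 1 to compound 2 (0.16 log units; that floor lies within the scatter), and it involves a different exchange, so no shift beyond the scatter is expected in this assay. The expected change is a 1.1-fold lower number from compound 2 to compound 3 (0.05 log units; within the scatter). For compound 3 the estimated value is 6000 nM, with an expected range from 2000 nM to 16000 nM.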

Compound 3, half-maximal inhibitory concentration: 5230 nM
Estimate against measurement, compound 3: 1.1-fold (0.06 log units) above, within the range that was stated.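

In this assay, putting piperidin-4-yl in place of 3-aminopropyl on the oxygen on the aromatic ring gives a 1.3-fold lower number from compound 2 to compound 3 (0.11 log units; within the scatter), so within these compounds this position takes a six-membered non-aromatic ring in place of an open chain with no shift beyond the scatter. The comparison with the carbamate-bearing side chain gives an at least 1.9-fold lower number from compound 1 to compound 3 (0.28 log units; that floor lies within the scatter), which is only a floor. Compound 1 stands at a limit of the assay and not at a number, so the true size of that step cannot be read: the limit of > 10000 nM in this assay, at which 1 of the 3 values shown sits.

The compounds shown leave open whether a carboxylic acid, a longer chain or a second amine on this oxygen would move the number beyond the scatter, since no step here firmly does. They also leave open the actual value of compound 1.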